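The source may hold more compounds than are shown below. What is called first, only, known or untested is meant among the compounds shown, and "the series" means these compounds.

Compound 2 `CC(=O)OC/C(=C\C1CCCCC1)C(=O)c1ccccc1` is measured only in a functional assay on T47D cells (Homo sapiens) for inhibition, read by sulforhodamine B assay, with a stated time of 48 h (a higher number here means a weaker inhibitor of growth, a lower number a stronger inhibitor of growth), where compound 2 gives 22000 nM. Among the compounds with values here, its only neighbour is compound 1 `O=C(/C(=C/c1ccc(Cl)cc1)CCl)c1ccccc1`, which in this assay gives 17000 nM; the two numbers lie within the scatter of each other, so no order between them can be read. Compound 3 `CC(=O)OC/C(=C\c1ccccc1Br)C(=O)c1ccccc1` is not yet measured. The change from compound 2 is 2-bromophenyl in place of cyclohexyl on a double-bonded chain carbon bound to a double-bonded chain carbon. Within the data shown here, no step between measured compounds speaks to this change, so the expected step of a 1.5-fold lower number from compound 2 to compound 3 (0.17 log units; within the scatter) is small, toward a lower number if any, and may not exceed the scatter. For compound 3 the expected value in this assay is 15000 nM, within the range from 5000 nM to 45000 nM.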

Compound 3, concentration for 50% growth inhibition: 17000 nM
The estimate for compound 3 lay 1.1-fold (0.05 log units) below the measured number; the measured number falls inside the stated range.
By their numbers in this assay, from the lowest: compounds 1, 3 and 2 (each within the scatter of the next).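

On a double-bonded chain carbon bound to a double-bonded chain carbon, 2-bromophenyl in place of cyclohexyl gives a 1.3-fold lower number from compound 2 to compound 3 (0.11 log units; within the scatter) in this assay. This first step at the position shows that the two six-membered rings, one aromatic and bromine-bearing, the other non-aromatic, cannot be told apart in this read-out. Nothing at hand bears on this result. On these data alone, whether an amine or a carboxylic acid at this carbon would give a number beyond the scatter stays open. The same holds for a longer chain there.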